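A few compounds are considered here, and "the series" means these few. Any claim that something is new, unique, unknown or untested is made for them only; others in the source may bear on it.

Compound 1 `C=C(CC)C(=O)c1ccc(OCC(=O)Nc2ccc(C(=O)O)cc2)c(Cl)c1Cl` gives 5000 nM
Compound 2 `C=C(CC)C(=O)c1ccc(OCC(=O)Nc2ccc(/C=C/C(=O)NO)cc2)c(Cl)c1Cl` gives 2600 nM
Compound 3 `C=C(CC)C(=O)c1ccc(OCC(=O)Nc2ccc(CC(=O)O)cc2)c(Cl)c1Cl` gives 3200 nM

In a functional assay on CLL cells (Homo sapiens) for cytotoxicity, read by MTT assay, with a stated time of 48 h (a lower number here means that less compound is needed, a higher number that more compound is needed for the effect), compound 1 does not stand apart from the other two, since the measured steps are a 1.9-fold lower number from compound 1 to compound 2 (0.28 log units; within the scatter) and a 1.6-fold lower number from compound 1 to compound 3 (0.19 log units; within the scatter) and the remaining pair differs by a 1.2-fold higher number from compound 2 to compound 3 (0.09 log units; within the scatter) in the same test.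

The unmeasured compound 4 `C=C(CC)C(=O)c1ccc(OCC(=O)NCCO)c(Cl)c1Cl` carries a larger change: 2-hydroxyethyl in place of 4-carboxyphenyl on an amide-type nitrogen. Put simply, this is 2-hydroxyethyl in place of 4-carboxyphenyl on an amide-type nitrogen. Going by the values given here, the measured steps only swap a group on the aromatic carbon of that ring, so they bear on this change indirectly, and no measured compound lacks the ring. Those swaps barely registered, which gives some grounds to expect no step beyond the scatter in this assay, though with real uncertainty in either direction.

The estimated step is a 1.2-fold higher number from compound 1 to compound 4 (0.08 log units; within the scatter) and it is only a rough expectation. For compound 4 the expected value is 6000 nM within an estimated range from 2500 nM to 15000 nM in this test.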

Compound 4, half-maximal effective concentration: > 25000 nM
Compound 4: a limit, no number (the forecaster's own chance of this, stated with the estimate: 10%); middle value at least 4.1-fold (0.61 log units) from the limit.
By their numbers in this assay, from the lowest: compounds 2, 3 and 1 (each within the scatter of the next). At a limit, above all of these: compound 4.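

Swapping the group on the aromatic carbon of the ring left the numbers within the scatter of one another, but replacing the whole 4-carboxyphenyl with 2-hydroxyethyl on the amide-type nitrogen registers clearly in this assay, giving an at least 5.0-fold higher number from compound 1 to compound 4 (0.69 log units; beyond the scatter). On these data alone, compound 4 stands at > 25000 nM, which is a limit of the assay and not a number, so the full size of this step stays unknown. Among these compounds, then, having the 4-carboxyphenyl on this nitrogen counts for more than which group its ring carries.

This single change removes the ring and shortens the group at once, and the compounds shown do not separate those two effects. A plain phenyl or a longer chain ending in a carboxylic acid on the same nitrogen would help tell them apart.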